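A few compounds are considered here, and "the series" means these few. Any claim that something is new, unique, unknown or untested is made for them only; others in the source may bear on it.

Measured so far:
- compound 1 `Clc1ccc(Cc2nn3c(Br)c(-c4ccc(Cl)cc4)nc3s2)cc1` — > 250000 nM
- compound 2 `N#CSc1c(-c2ccc(Cl)cc2)nc2sc(Cc3ccc(Cl)cc3)nn12` — 20000 nM

Among the compounds with values here, in a functional assay on HeLa cells (Homo sapiens) for cytotoxicity, with a stated time of 72 h (a higher number here means a weaker inhibitor, a lower number a stronger inhibitor), compound 2 gives 20000 nM, the only number among the values shown. Compound 1 reaches only a limit of the assay, > 250000 nM. Within the data shown here, the single measured step, an at least 12-fold lower number from compound 1 to compound 2 (1.09 log units; beyond the scatter), concerns the substituent on the shared core and starts from the limit of > 250000 nM in this assay, at which 1 of the 2 values shown sits, so its size is known only as a lower bound.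

Compound 3 `N#CSc1c(-c2ccc([N+](=O)[O-])cc2)nc2sc(Cc3ccc(Cl)cc3)nn12` differs from compound 2 by nitro in place of chloro on an aromatic carbon. Among the measured compounds shown here, no measured step touches this aryl substituent; the one step available, from compound 1 to compound 2, changes the core position and says nothing about the aryl ring. With no comparison bearing on the change, the expectation is a step no larger than the scatter, no change at the digits printed from compound 2 to compound 3 (within the scatter). On that basis compound 3 is estimated at 20000 nM in this assay, with a range from 6000 nM to 70000 nM.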

Compound 3, half-maximal inhibitory concentration: 16000 nM
For compound 3 the middle estimate is 1.3-fold (0.10 log units) above the measured one, within the range that was stated.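

In this assay, within the data shown here, the first reading on the aryl ring comes from the change from 4-chlorophenyl to 4-nitrophenyl with the cyanosulfanyl group held in place: a 1.3-fold lower number from compound 2 to compound 3 (0.10 log units; within the scatter). In this pair the read-out does not separate chloro from nitro, even though nitro brings hydrogen-bond acceptors that chloro lacks and is the larger group by heavy atoms. The only step beyond the scatter remains the one on the shared core, an at least 12-fold lower number from compound 1 to compound 2 (1.09 log units; beyond the scatter), and no measurement shown gives a reason for the flat result at the aryl ring.

Among these compounds, open is whether an amine, a carboxylic acid or a methoxy group on the same aromatic carbon would also stay within the scatter of compound 2, since chloro and nitro are the only two groups compared there. Also open, as far as these compounds go, is whether a longer chain in place of the cyanosulfanyl group would keep the activity seen in compound 2, and whether the aryl change reads the same when bromo occupies that core position.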